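The compounds below may be only part of what the source reports. "The series", "measured", "known", "first", "only" and "open" are said of these compounds alone.

Measured so far:
compound 1 `COc1cccc(CNCCCNc2ccnc3cc(-c4ccccc4)ccc23)c1O` — 9.47
compound 2 `COc1ccc(F)cc1CNCCCNc1ccnc2cc(-c3cccc4ccccc34)ccc12` — 9.47
compound 3 `COc1cccc(CNCCCNc2ccnc3cc(-c4ccc(C(F)(F)F)cc4)ccc23)c1O` — 9.47

The three measured compounds share a core and differ at the aromatic group attached to it and, in the case of compound 2, in the left-hand part as well. In a physicochemical assay for acid dissociation, compound 1 gives 9.47. In this assay compound 2 gives 9.47. In this assay compound 3 gives 9.47. Among the compounds with values here, the only step that can be followed one change at a time, no change at the digits printed from compound 1 to compound 3 (within the scatter), shows that exchanging the group on the aromatic carbon leaves the read-out where it was. Compound 3 thus stands level with compounds 1 and 2, with no difference that goes beyond the scatter in either direction.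

Compound 4 `COc1cccc(CNCCCNc2ccnc3cc(-c4cccc5ccccc45)ccc23)c1O` has not yet been measured. It differs from compound 3 in one place: naphthalen-1-yl in place of 4-(trifluoromethyl)phenyl on an aromatic carbon. The step from compound 1 to compound 3 is the one that bears on this change, since it also swaps the group on that aromatic carbon, and it was flat. Compound 2, which already carries naphthalen-1-yl, gives the same value as compounds 1 and 3. A step of no size beyond the scatter, no change at the digits printed from compound 3 to compound 4 (within the scatter), is therefore expected here. For compound 4 the expected value in this assay is 9.47, between 9.17 and 9.77.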

Compound 4, acid dissociation constant: 9.47
Beside the measured number, compound 4's estimate shows no gap at the digits printed, within the range that was stated.
By their numbers in this assay, from the lowest: compounds 1, 2, 3 and 4 (each within the scatter of the next).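

In this assay, naphthalen-1-yl in place of 4-(trifluoromethyl)phenyl gives no change at the digits printed from compound 3 to compound 4 (within the scatter) and naphthalen-1-yl in place of phenyl gives no change at the digits printed from compound 1 to compound 4 (within the scatter), so three different groups have now been compared directly on this aromatic carbon, with the left-hand part of the molecule held fixed, and all three read the same. Within the data shown here, compound 2 differed from the earlier compounds in two places, but compound 4 now isolates the other part of the molecule: 2-hydroxy-3-methoxyphenyl in place of 5-fluoro-2-methoxyphenyl on the saturated chain carbon bound to an amine nitrogen gives no change at the digits printed from compound 2 to compound 4 (within the scatter), so this exchange also leaves the read-out level when naphthalen-1-yl is in place. The data offer no independent measurement that explains why these read-outs stay level.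

All the groups compared on the aromatic carbon contain only carbon rings, so a pyridine ring or a phenyl ring carrying an amine or a carboxylic acid could still behave differently there. The compounds shown also keep the same chain throughout, which leaves open what a longer chain would do to the read-out in this assay at all.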